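Methyl to chloro: the step from compound 3 to compound 4

The compounds below may be only part of what the source reports. "The series", "measured", "known", "first", "only" and "open" are said of these compounds alone.

Compound 1 `COC(=O)N1N=C(c2cccc(OC)c2)CC1c1cc(OC)c(OC)c(OC)c1`: 1870 nM
Compound 2 `COC(=O)N1N=C(c2cccc(O)c2)CC1c1cc(OC)c(OC)c(OC)c1`: 650 nM
Compound 3 `COC(=O)N1N=C(c2cccc(C)c2)CC1c1cc(OC)c(OC)c(OC)c1`: 980 nM

These numbers come from a functional assay on HepG2 cells (Homo sapiens) for antiproliferative activity, read by MTT assay, with a stated time of 48 h; on this read-out higher numbers stand for weaker inhibition of growth and lower numbers for stronger inhibition of growth. Compound 3 is not separated from either of the other two, as the data show a 1.9-fold lower number from compound 1 to compound 3 (0.28 log units; within the scatter) and a 1.5-fold higher number from compound 2 to compound 3 (0.18 log units; within the scatter). Only a 2.9-fold lower number from compound 1 to compound 2 (0.46 log units; beyond the scatter) goes beyond the scatter, and it is modest. Compound 4 `COC(=O)N1N=C(c2cccc(Cl)c2)CC1c1cc(OC)c(OC)c(OC)c1` carries chloro in place of methyl on an aromatic carbon, which is chloro in place of methyl on an aromatic carbon. Within the data shown here, no measured compound holds chloro, so the guide is the two steps that end in the methyl of compound 3, and both stayed within the scatter. The expected change is therefore none beyond the scatter, with an estimated 1.1-fold lower number from compound 3 to compound 4 (0.04 log units; within the scatter). Compound 4 is expected at 900 nM, within an estimated range of 400 nM to 2000 nM.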

Compound 4, concentration for 50% growth inhibition: 1240 nM
Estimate against measurement, compound 4: 1.4-fold (0.14 log units) below; measured number inside the range.
By their numbers in this assay, from the lowest: compounds 2, 3, 4 and 1 (each within the scatter of the next, the first and the last beyond it).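

In this assay, chloro on this aromatic carbon stays unseparated from all three earlier groups, with a 1.3-fold higher number from compound 3 to compound 4 (0.10 log units; within the scatter), a 1.9-fold higher number from compound 2 to compound 4 (0.28 log units; within the scatter) and a 1.5-fold lower number from compound 1 to compound 4 (0.18 log units; within the scatter). Chloro thus joins methyl in lying within the scatter of both hydroxy and methoxy, and the only step beyond it remains a 2.9-fold lower number from compound 1 to compound 2 (0.46 log units; beyond the scatter). No evidence is available that bears on why these groups fall so close together. Still open is whether an amine, a carboxylic acid or a longer chain here would move the number beyond the scatter of these compounds. As far as these compounds go, whether fluoro or bromo would read like chloro is equally open.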